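Amide variation on the shared core: compound 3 to compound 4

This account rests on a few compounds, and the source may have more. Where it says the series, first, only, none or still open, it means among the compounds named here.

Three amides on one shared core have been tested in a functional assay on MDA-MB-468 cells (Homo sapiens) for antiproliferative activity, read by MTT assay, with a stated time of 72 h; a lower number here means a stronger inhibitor, a higher number a weaker inhibitor. Compound 1 `CS(=O)(=O)c1ccc(C(=O)Nc2ccc(Cl)c(-c3nnc4c(Cl)cccn34)c2)c(Cl)c1` reaches only the limit of the assay, > 100000 nM. Compound 2 `O=C(Nc1ccc(Cl)c(-c2nnc3c(Cl)cccn23)c1)c1ccccc1` likewise gives a limit, > 100000 nM. Compound 3 `O=C(Nc1ccc(Cl)c(-c2nnc3c(Cl)cccn23)c1)c1ccon1` also stands at a limit, > 100000 nM, so no number is known for it; all three values sit at the same limit (the limit of > 100000 nM in this assay, at which 3 of the 3 values shown sit). Going by the values given here, the one single-point step among them, a step that the two limits leave unreadable from compound 2 to compound 3, is therefore unreadable, as neither end is a number.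

Compound 4 `O=C(Nc1ccc(Cl)c(-c2nnc3c(Cl)cccn23)c1)c1ccc(Cl)cc1Cl` is not yet measured. Relative to compound 3 it is changed at the carbonyl carbon of the amide: 2,4-dichlorophenyl in place of 1,2-oxazol-3-yl on a carbonyl carbon. Among the compounds with values here, the only measured step on that same carbonyl carbon is the unreadable one from compound 2 to compound 3, so it gives no size in either direction. Compound 1, which also carries a chlorinated phenyl on the carbonyl carbon but differs from compound 3 in more than one place, shows only a limit as well.

With every value in the series at the limit, the step that the limit leaves unreadable from compound 3 to compound 4 is expected to be flat, and compound 4 is expected to give 150000 nM, within 40000 nM to 500000 nM, most probably again only as a limit.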

Compound 4, half-maximal inhibitory concentration: 21600 nM
Compound 4: the middle estimate sits 6.9-fold (0.84 log units) above what was measured, outside the stated range (below it).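

In this assay, the carbonyl carbon of the amide proves able to move the series off the limit, with 2,4-dichlorophenyl in place of 1,2-oxazol-3-yl giving an at least 4.6-fold lower number from compound 3 to compound 4 (0.66 log units; beyond the scatter); these sizes are only minimum sizes, since each starting compound stands at a limit: the limit of > 100000 nM in this assay, at which 3 of the 4 values shown sit.

Phenyl on the same carbon does not give a measurable value, and the change to 2,4-dichlorophenyl gives an at least 4.6-fold lower number from compound 2 to compound 4 (0.66 log units; beyond the scatter), so the chloro groups on that ring separate a measurable compound from one at the limit. A chlorinated phenyl on the carbonyl carbon is not sufficient by itself, as chloro in place of methylsulfonyl on an aromatic carbon gives an at least 4.6-fold lower number from compound 1 to compound 4 (0.66 log units; beyond the scatter).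

From the compounds shown here alone, the true size of these steps stays open, and the steps that join only limits cannot be read. Also open, going by these compounds, is whether a phenyl bearing a single chloro would leave the limit, and whether bromo, methyl or methoxy could take the place of the chloro groups on that ring.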